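The source may report more compounds than this note shows. Statements on the series, on what has been measured and on what is new or still open speak of the compounds shown alone.

Measured in a functional assay on HT-1080 cells (Homo sapiens) for antiproliferative activity, read by MTT assay, with a stated time of 72 h; on this read-out lower numbers stand for stronger inhibition and higher numbers for weaker inhibition:

- Compound 1 `CCOC(=O)c1cc(-c2cc(OC)c(OC)c(OC)c2)c(-c2ccc3ccccc3c2)s1`: 1150 nM
- Compound 2 `COc1cc(-c2ccsc2-c2ccc3ccccc3c2)cc(OC)c1OC`: 5430 nM
- Compound 3 `CCOC(=O)c1cc(-c2ccc(OC)cc2)c(-c2cc(OC)c(OC)c(OC)c2)s1`: 7630 nM

In this assay, compound 3 at 7630 nM cannot be told apart from compound 2 at 5430 nM, and both numbers lie above that of compound 1.

The next compound is compound 4 `CCOC(=O)c1cc(-c2ccc(OC)c(O)c2)c(-c2cc(OC)c(OC)c(OC)c2)s1`, which is still unmeasured. It differs from compound 3 by one change, hydroxy in place of hydrogen on an aromatic carbon, which turns 4-methoxyphenyl into 3-hydroxy-4-methoxyphenyl: hydroxy in place of hydrogen on an aromatic carbon.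

Among the measured compounds shown here, no measured step touches this ring, so the evidence is indirect. For the measured compounds named here, the only step available, a 4.7-fold higher number from compound 1 to compound 2 (0.67 log units; beyond the scatter), concerns the ethoxycarbonyl group instead, and it is modest. It offers only a rough guide to size and says nothing firm about direction. Compound 1 at 1150 nM shows that this small family can reach lower numbers than compound 3, so a modest fall is the cautious expectation.

The expected change is a 2.5-fold lower number from compound 3 to compound 4 (0.41 log units; beyond the scatter). For compound 4 the estimate is 3000 nM, with an expected range from 400 nM to 12000 nM.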

Compound 4, half-maximal inhibitory concentration: 82600 nM
Estimate against measurement, compound 4: 28-fold (1.44 log units) below; measured number outside the range, above it.
By their numbers in this assay, from the lowest: compound 1; then compounds 2 and 3 (each within the scatter of the next); then compound 4.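

In this assay, placing a hydroxy group on the aromatic carbon ortho to the methoxy group gives an 11-fold higher number from compound 3 to compound 4 (1.03 log units; beyond the scatter), so this ring position does not tolerate every small change. A single added oxygen atom is enough to lift compound 4 clear of all three earlier compounds, making it the weakest inhibitor of the four. The data shown offer no measurement that explains this loss.

Still open, from the compounds shown here alone, is whether the loss belongs to the hydroxy group itself or to any addition at this carbon, which an amine or a fluorine on the same carbon would help to separate. Going by these compounds, it is also open whether a hydroxy group elsewhere on this ring, or this one on a compound lacking the ethoxycarbonyl group, would behave the same way.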